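The source may hold more compounds than are shown below. What is called first, only, known or untested is meant among the compounds shown, and "the series" means these compounds.

Within the data shown here, in a functional assay on DU-145 cells (Homo sapiens) for antiproliferative activity, read by WST assay, with a stated time of 3 days (on this read-out lower numbers stand for stronger inhibition and higher numbers for weaker inhibition), compound 1 (`CCOc1c(-c2cc(OC)c(OC)c(OC)c2)oc2ccccc2c1=O`) gives 6200 nM, the only measured number in this short series. Compound 2 (`CCCCOc1c(-c2cc(OC)c(OC)c(OC)c2)oc2ccccc2c1=O`) reads > 50000 nM, which is a limit of the assay and not a number. Compound 3 (`CCC(C)Oc1c(-c2cc(OC)c(OC)c(OC)c2)oc2ccccc2c1=O`) reads > 50000 nM, also a limit. Compound 3 therefore stands at the limit of > 50000 nM in this assay, at which 2 of the 3 values shown sit.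

The measured steps show an at least 8.0-fold higher number from compound 1 to compound 2 (0.90 log units; beyond the scatter) and an at least 8.0-fold higher number from compound 1 to compound 3 (0.90 log units; beyond the scatter). Between the two limits there is a step that the two limits leave unreadable from compound 2 to compound 3.

Compound 4 (`CCN(CC)CCCOc1c(-c2cc(OC)c(OC)c(OC)c2)oc2ccccc2c1=O`) carries 3-(diethylamino)propyl in place of sec-butyl on an oxygen on an aromatic ring. Among the measured compounds shown here, the steps from compound 1 bear on this change only loosely, since no measured compound carries the diethylamino group. Taken alone, they would suggest that compound 4 stays at the limit in this assay. Since compound 1 reaches 6200 nM on the shared core, a return into the measurable range is nevertheless expected. A further reading at the limit is still possible for compound 4. The expected step, toward a lower number, is an at least 5.0-fold lower number from compound 3 to compound 4 (0.69 log units; beyond the scatter). For compound 4 the estimate is 10000 nM, with an expected range of 2000 nM to 50000 nM.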

Compound 4, half-maximal inhibitory concentration: > 50000 nM
Compound 4: a limit, no number; the forecaster's own chance of this, stated with the estimate: 25%; middle value at least 5.0-fold (0.69 log units) away from the limit.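

In this assay compound 4 reads > 50000 nM, which is a limit of the assay and not a number. The change to 3-(diethylamino)propyl on this oxygen on an aromatic ring gives an at least 8.0-fold higher number from compound 1 to compound 4 (0.90 log units; beyond the scatter), so the loss seen with the butyl and sec-butyl chains now extends to a longer chain that carries an amine. The steps among compound 2, compound 3 and compound 4 cannot be read, and ethyl remains the only group at this position with a measured number, while the rest of the series sits at one limit: the limit of > 50000 nM in this assay, at which 3 of the 4 values shown sit.

On these data alone, how a propyl or methyl group on this oxygen would read remains open, and with it the point between ethyl and butyl at which the measurable range ends. Also open, as far as these compounds go, is whether a shorter amine chain such as 2-(dimethylamino)ethyl, or a chain ending in a carboxylic acid, would return to the measurable range on the shared core.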